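Swapping the amide aryl group on a shared flavonol core

The source may report more compounds than this note shows. Statements on the series, on what has been measured and on what is new or still open speak of the compounds shown alone.

The two measured compounds share one core and differ only in the aryl group on the carbonyl carbon of the amide. Compound 1 `O=C(Nc1cccc(-c2oc3cc(-c4ccc(F)cc4)ccc3c(=O)c2O)c1)c1ccc(Cl)cc1` carries a 4-chlorophenyl there and in a functional assay on HepG2 cells (Homo sapiens) for antiproliferative activity, read by CCK-8 assay, with a stated time of 72 h (a higher number here means a weaker inhibitor, a lower number a stronger inhibitor), compound 1 gives 11000 nM. Compound 2 `O=C(Nc1cccc(-c2oc3cc(-c4ccc(F)cc4)ccc3c(=O)c2O)c1)c1ccc(F)cc1F` carries a 2,4-difluorophenyl instead, and in this assay compound 2 gives 26400 nM. This is the higher of the two numbers seen so far: the step of a 2.4-fold higher number from compound 1 to compound 2 (0.38 log units; beyond the scatter) puts compound 2 beyond the scatter of compound 1, so compound 2 stands as the weaker of the pair.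

Compound 3 `COc1ccccc1C(=O)Nc1cccc(-c2oc3cc(-c4ccc(F)cc4)ccc3c(=O)c2O)c1` is not yet measured. It differs from compound 2 by 2-methoxyphenyl in place of 2,4-difluorophenyl on a carbonyl carbon. For the measured compounds named here, the only step that bears on this position is the one from compound 1 to compound 2, and it was modest. Going by the values given here, with no direct precedent for a methoxyphenyl on this carbonyl, the most reasonable expectation is a step in this assay of no more than modest size, in either direction, quite possibly within the scatter; the estimate here is a slight lowering, a 1.7-fold lower number from compound 2 to compound 3 (0.22 log units; within the scatter). Compound 3 is therefore expected at about 16000 nM, within a range of 5000 nM to 50000 nM.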

Compound 3, half-maximal inhibitory concentration: 14500 nM
Estimate against measurement, compound 3: 1.1-fold (0.04 log units) above; low and high end bracket the measured number.
By their numbers in this assay, from the lowest: compounds 1, 3 and 2 (each within the scatter of the next, the first and the last beyond it).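

In this assay, the 2-methoxyphenyl group on the carbonyl carbon separates from neither earlier aryl group: exchanging it for 2,4-difluorophenyl gives a 1.8-fold lower number from compound 2 to compound 3 (0.26 log units; within the scatter), and exchanging it for 4-chlorophenyl gives a 1.3-fold higher number from compound 1 to compound 3 (0.12 log units; within the scatter). Compound 3 therefore bridges the one gap seen so far, since only compound 1 and compound 2 stand beyond the scatter of each other, and this position accepts an aryl group with a hydrogen-bond acceptor and no halogen without a step beyond the scatter from either halogenated neighbour. No measurement given here accounts for these numbers, so the result describes the size of the steps and offers no explanation for them.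

The three compounds all carry a substituted phenyl on this carbonyl, so they leave open how the number would respond to an unsubstituted phenyl, a 4-methoxyphenyl, or a saturated group such as cyclohexyl. They also leave open whether an amine or a carboxylic acid on this aryl ring would produce a step beyond the scatter from compound 3.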